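This account rests on a few compounds, and the source may have more. Where it says the series, first, only, none or still open, it means among the compounds named here.

Measured in a functional assay (Mus musculus) for inhibition, with a stated time of 5 days; a higher number here means a weaker inhibitor, a lower number a stronger inhibitor:
- compound 1 `O=C(O)/C=C/c1cn(-c2ccc(O)cc2)nc1-c1ccc(O)cc1`: > 100000 nM, a limit
- compound 2 `O=Cc1cn(-c2ccc(O)cc2)nc1-c1cccc(O)c1`: 42000 nM
- compound 3 `O=Cc1cn(-c2ccc(O)cc2)nc1-c1ccc(O)c(O)c1`: 12000 nM

Of the two exact numbers, the lower belongs to compound 3, at 12000 nM. The entry for compound 1 is a limit and not a number.

Compound 4 `CCOC(=O)/C=C/c1cn(-c2ccc(O)cc2)nc1-c1ccc(O)c(O)c1` differs from compound 3 by one change, 2-(ethoxycarbonyl)ethenyl in place of formyl on an aromatic carbon. Going by the values given here, the only measured step, a 3.5-fold lower number from compound 2 to compound 3 (0.54 log units; beyond the scatter), is a hydroxy change elsewhere and offers a modest yardstick of size only. Among the compounds with values here, no measured step touches this group, so no clear shift in this assay is expected, and the direction stays open. The expected change is a 1.3-fold higher number from compound 3 to compound 4 (0.10 log units; within the scatter). Compound 4 is estimated at 15000 nM, with an expected range of 4000 nM to 60000 nM.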

Compound 4, half-maximal inhibitory concentration: 6200 nM
The estimate for compound 4 lay 2.4-fold (0.38 log units) above the measured number, and the stated range covers the measured number.
By their numbers in this assay, from the lowest: compounds 4 and 3 (each within the scatter of the next); then compound 2. At a limit, above all of these: compound 1.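

Going by these compounds alone, the change gives a 1.9-fold lower number from compound 3 to compound 4 (0.29 log units; within the scatter) in this assay and is the first step at this position on the five-membered aromatic ring. With the rest of compound 3 held fixed, formyl (2 heavy atoms) gives way to 2-(ethoxycarbonyl)ethenyl (7 heavy atoms) with no shift that can be told from the scatter, so on this core the formyl group is not required for the activity seen. Nothing shown accounts for this step.

Still open, as far as these compounds go, is how a carboxylic acid or an amide in place of the ethyl ester would read on the core of compound 4. Also open, from the compounds shown here alone, is whether an amine or a longer chain would be accepted at this position.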